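This account rests on a few compounds, and the source may have more. Where it says the series, first, only, none or still open, it means among the compounds named here.

- Compound 1 `O=C1C(=O)N(CCCCCn2cc(COc3cc(=O)oc4ccccc34)nn2)c2ccc(F)cc21`: 59%
- Compound 2 `O=C1C(=O)N(CCCn2cc(COc3cc(=O)oc4ccccc34)nn2)c2ccc(I)cc21`: 65%

In a functional assay on HCT-116 cells (Homo sapiens) for inhibition, read by sulforhodamine B assay, with a stated time of 48 h, tested at 50 uM (on this read-out higher numbers stand for more inhibition of growth at the one concentration tested and lower numbers for less inhibition of growth), compound 1 gives 59% and compound 2 gives 65%, two values that lie within the scatter of each other. Compound 3 `O=C1C(=O)N(CCCCCn2cc(COc3cc(=O)oc4ccccc34)nn2)c2ccccc21` departs from compound 1 by hydrogen in place of fluoro on an aromatic carbon, with hydrogen in place of fluoro on an aromatic carbon. For the measured compounds named here, the two measured compounds differ in more than one place, so no single-change step is available as a guide. No change beyond the scatter is therefore expected in this assay, and the estimate starts from compound 1 at 59%. The expected a number 4 percentage points lower from compound 1 to compound 3 (within the scatter) is small. For compound 3 the estimated value is 55%, with an expected range of 40% to 70%.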

Compound 3, percent growth inhibition at one concentration: 65%
Beside the measured number, compound 3's estimate is 10 percentage points below it; low and high end bracket the measured number.
By their numbers in this assay, from the lowest: compounds 1, 2 and 3 (each within the scatter of the next).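

In this assay, for the compounds shown here, hydrogen in place of fluoro on an aromatic carbon gives a number 6 percentage points higher from compound 1 to compound 3 (within the scatter) as the first comparison in which only one place differs. At this position of the shared core, then, losing the fluoro leaves growth inhibition at the one concentration tested without a change beyond the scatter, so the fluoro is not needed to keep this level of inhibition. No measurement offered here bears on this result.

Going by these compounds, whether an amine or a carboxylic acid on this aromatic carbon would move the number beyond the scatter remains open. So does whether the same exchange of fluoro for hydrogen would give a similar step with a shorter chain.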